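Chloro-to-amino exchange on the two benzyl isomers

This account rests on a few compounds, and the source may have more. Where it says the series, first, only, none or still open, it means among the compounds named here.

The series comprises compound 1 `ClCc1ccccc1Cn1cnc2c(Cl)nc(Cl)nc21`, compound 2 `ClCc1cccc(Cn2cnc3c(Cl)nc(Cl)nc32)c1`, compound 3 `Nc1nc(Cl)c2ncn(Cc3ccccc3CCl)c2n1` and the unmeasured compound 4 `Nc1nc(Cl)c2ncn(Cc3cccc(CCl)c3)c2n1`. In a functional assay on OVCAR-3 cells (Homo sapiens) for cytotoxicity, read by sulforhodamine B assay, with a stated time of 48 h (a lower number here means a stronger inhibitor of growth, a higher number a weaker inhibitor of growth), compound 1 gives 510 nM, compound 2 gives 3230 nM and compound 3 gives 20000 nM. Compound 2 stands second highest of the three measured values. How the core of compound 1 and the core of compound 2 differ is not broken down here; the two share the same atoms joined differently.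

From compound 1 to compound 3 the change is amino in place of chloro on an aromatic carbon, and in this assay it made a step of a 39-fold higher number from compound 1 to compound 3 (1.59 log units; beyond the scatter). For the measured compounds named here, from compound 2 to compound 4 the change is amino in place of chloro on an aromatic carbon, the same change at the same kind of place, so the same size of step is the expectation, resting on the single measured step from compound 1 to compound 3.

Compound 4 is therefore expected to give a step of a 25-fold higher number from compound 2 to compound 4 (1.39 log units; beyond the scatter) in this assay. The estimated value for compound 4 is 80000 nM, with a range from 20000 nM to 300000 nM.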

Compound 4, concentration for total growth inhibition: 2290 nM
Compound 4: middle estimate off by 35-fold (1.54 log units), on the high side; measured number below the stated range.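

In this assay, amino in place of chloro on an aromatic carbon gives a step of a 1.4-fold lower number from compound 2 to compound 4 (0.15 log units; within the scatter), so on the core of compound 2 this exchange shows no readable effect. The exchange therefore does not carry over in size between the two cores, although it is the same change at the same kind of place: the same change on two cores in this assay, a 39-fold higher number (1.59 log units; beyond the scatter) from compound 1 to compound 3 and a 1.4-fold lower number (0.15 log units; within the scatter) from compound 2 to compound 4, 55-fold (1.74 log units) apart, beyond the scatter of two such steps

This shows that, within these four compounds, the size of the step depends on the core; it does not show which difference between the two cores, which share the same atoms joined differently, is responsible, nor how the exchange would behave on any other core.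

For the compounds shown here, with only two cores, it remains open whether the large step or the step within the scatter is the more typical outcome for this exchange on related cores. On these data alone, it also remains open whether a methylamine, a methoxy group or a thiol in the same place would differ between the two cores as amino does.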